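Compound 2 to compound 4: chloro in place of methyl

This account rests on a few compounds, and the source may have more. Where it says the series, first, only, none or still open, it means among the compounds named here.

Going by the values given here, in a functional assay on HeLa cells (Homo sapiens) for cytotoxicity, read by LDH release, with a stated time of 48 h (a lower number here means a stronger inhibitor, a higher number a weaker inhibitor), three compounds have values so far. Compound 1 `Cn1cnc(C(=O)NNC(=O)COc2ccc(C(=O)c3ccccc3)cc2)c1` gives 31900 nM. Compound 2 `Cc1ccc(C(=O)c2cc(F)c(OCC(=O)NNC(=O)c3ccc(=O)oc3)c(Cl)c2)cc1` gives 26900 nM. Compound 3 `Cc1ccc(C(=O)c2cc(F)c(OCC(=O)NNC(=O)c3cn(C)cn3)c(Cl)c2)cc1` gives 10400 nM. Compound 2 lies within the scatter of compound 1, and the two stand together at the high end of these numbers, while compound 3 is separated from compound 2 by more than the scatter.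

Compound 4 `O=C(COc1c(F)cc(C(=O)c2ccc(Cl)cc2)cc1Cl)NNC(=O)c1ccc(=O)oc1` has not yet been measured. It differs from compound 2 by chloro in place of methyl on an aromatic carbon, para to a large group, so that 4-methylphenyl becomes 4-chlorophenyl.

Among the compounds with values here, the only measured step between compounds differing in one place, a 2.6-fold lower number from compound 2 to compound 3 (0.41 log units; beyond the scatter), is modest and concerns a different exchange, on a carbonyl carbon. Within the data shown here, it sets no size for the present change, and no measured pair isolates methyl against chloro at this place. No shift beyond the scatter is therefore expected in this assay, and no direction is favoured. The expected step is a 1.2-fold lower number from compound 2 to compound 4 (0.07 log units; within the scatter). For compound 4 the estimated value is 23000 nM, with an expected range from 10000 nM to 50000 nM.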

Compound 4, half-maximal inhibitory concentration: 85100 nM
Estimate against measurement, compound 4: 3.7-fold (0.57 log units) below, and the stated range ends below it.
By their numbers in this assay, from the lowest: compound 3; then compounds 2 and 1 (each within the scatter of the next); then compound 4.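

Chloro in place of methyl on this aromatic carbon, para to a large group, gives a 3.2-fold higher number from compound 2 to compound 4 (0.50 log units; beyond the scatter) in this assay. This position therefore responds to a change of one heavy atom for one heavy atom, with no ring, hydrogen-bond donor, hydrogen-bond acceptor or net charge entering or leaving, and 4-chlorophenyl gives the weaker inhibitor of this pair. The step is also modest but runs the opposite way to a 2.6-fold lower number from compound 2 to compound 3 (0.41 log units; beyond the scatter), showing that the number can move in either direction from compound 2, depending on which of these two places is changed, and no measurement at hand accounts for the shift at the 4-methylphenyl end.

With a single pair at this place, the compounds shown leave open whether the higher number tracks chloro specifically or whether other groups there, such as methoxy or dimethylamino, would give a similar step. They also leave open whether the same exchange gives a step of similar size and direction with the group on the carbonyl carbon of compound 3.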